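The compounds below may be only part of what the source reports. "The series", "measured", "known", "first", "only" and "open" are said of these compounds alone.

In an ADME assay on cells (Fibroblast) for cytotoxicity (a higher number here means a weaker inhibitor, a lower number a stronger inhibitor), compound 1 `O=C(/C=C\c1ccccc1)N[C@@H](CSCCCC(=O)NO)C(=O)NCc1ccccc1` gives 800 nM and compound 2 `CN(C)c1ccc(NC(=O)[C@H](CSCCCC(=O)NO)NC(=O)c2ccc(N(C)C)cc2)cc1` gives 600 nM, two values within the scatter of each other. Compound 3 `CN(C)c1ccc(C(=O)N[C@@H](CSCCCC(=O)NO)C(=O)Nc2ccc(-c3ccccc3)cc2)cc1` differs from compound 2 in one place: phenyl in place of dimethylamino on an aromatic carbon, para to a large group. Going by the values given here, no measured step covers this change, so the expectation is anchored on compound 2 at 600 nM. No shift beyond the scatter is expected, and the estimated step is a 1.2-fold lower number from compound 2 to compound 3 (0.08 log units; within the scatter). For compound 3 the expected value is 500 nM, with an estimated range of 170 nM to 1500 nM.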

Compound 3, half-maximal inhibitory concentration: 320 nM
Compound 3: middle estimate off by 1.6-fold (0.19 log units), on the high side; the measured number falls inside the stated range.
By their numbers in this assay, from the lowest: compounds 3, 2 and 1 (each within the scatter of the next, the first and the last beyond it).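

In this assay, going by these compounds alone, the first single-place comparison gives a 1.9-fold lower number from compound 2 to compound 3 (0.27 log units; within the scatter) for phenyl in place of dimethylamino on an aromatic carbon. At this position, a six-membered aromatic ring of carbon only therefore reads the same as dimethylamino, a group with no ring, within the scatter. Nothing available bears on the reason for this reading.

One pair sets no trend for this position. Going by these compounds, how a carboxylic acid or a primary amine would read in the same place remains open.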